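A few compounds are considered here, and "the series" means these few. Any claim that something is new, unique, unknown or untested is made for them only; others in the source may bear on it.

Series notes. Compound 1 `COc1cc2ncnc(NNC(=S)NC(=O)c3ccc(C(F)(F)F)cc3)c2cc1OC` and compound 2 `COc1cc2ncnc(NNC(=S)NC(=O)c3ccccc3C)c2cc1OC` share the same core and differ only in the aryl group on the carbonyl carbon. In a functional assay on CNE-2 cells (Homo sapiens) for cytotoxicity, read by MTT assay, with a stated time of 72 h (on this read-out higher numbers stand for weaker inhibition and lower numbers for stronger inhibition), compound 1 gives 16500 nM, and compound 2 gives 10500 nM. The step of a 1.6-fold lower number from compound 1 to compound 2 (0.20 log units; within the scatter) is within the scatter, so the two numbers are not distinguishable, and compound 2 stands alongside compound 1 rather than apart from it.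

Compound 3 `COc1cc2ncnc(NNC(=S)NC(=O)c3ccc(F)cc3)c2cc1OC` is the next member: 4-fluorophenyl in place of 2-methylphenyl on a carbonyl carbon. Among the compounds with values here, the only measured step that bears on this change is a 1.6-fold lower number from compound 1 to compound 2 (0.20 log units; within the scatter), an exchange of the same aryl group, and it stayed within the scatter. On that basis no step beyond the scatter is expected for compound 3 in this assay, and the expected step is a 1.1-fold higher number from compound 2 to compound 3 (0.06 log units; within the scatter). The estimated value for compound 3 is 12000 nM, with a range from 5000 nM to 30000 nM.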

Compound 3, half-maximal inhibitory concentration: 16100 nM
Compound 3: the middle estimate sits 1.3-fold (0.13 log units) below what was measured, within the range that was stated.
By their numbers in this assay, from the lowest: compounds 2, 3 and 1 (each within the scatter of the next).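

In this assay the exchange of 2-methylphenyl for 4-fluorophenyl on the carbonyl carbon gives a 1.5-fold higher number from compound 2 to compound 3 (0.19 log units; within the scatter) and stays within the scatter, as does the exchange of trifluoromethyl for fluoro on the aromatic carbon, which gives a 1.0-fold lower number from compound 1 to compound 3 (0.01 log units; within the scatter) in this series. Three different aryl groups on this carbonyl carbon, including a pair that differs only in one group on the aromatic ring, therefore leave the numbers indistinguishable, and no order can be drawn among compound 1, compound 2 and compound 3. No measurement at hand accounts for this lack of separation.

As far as these compounds go, it remains open whether a dimethylamino group or a carboxylic acid on the aromatic ring, or a longer alkyl chain in place of the aryl group, would give a step beyond the scatter. From the compounds shown here alone, whether changes to the methoxy groups on the shared core would do so also remains open.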